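A few compounds are considered here, and "the series" means these few. Any claim that something is new, unique, unknown or untested is made for them only; others in the source may bear on it.

Of the compounds shown here, three built on one shared core have been measured for how fast they cross an artificial membrane. Compound 1 `CC(C)c1ccc(NC2=NCCC3(CCCCC3)S2)cc1` gives 15.7 10^-6 cm/s in a physicochemical assay for permeability; a lower number here means that the compound crosses the layer more slowly, a higher number that the compound crosses the layer faster. Compound 3 `Cc1ccc(NC2=NCCC3(CCCCC3)S2)cc1Cl` gives 23.9 10^-6 cm/s in this assay, and compound 2 `CCNC1=NCCC2(CCCCC2)S1` gives 8.78 10^-6 cm/s. Among these three numbers compound 1 holds the second highest place, with compound 3 the nearest and compound 2 the furthest, yet neither gap reaches beyond the usual scatter of repeated measurements, so the three readings cannot be told apart with confidence.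

The next compound, compound 4 `Nc1ccc(NC2=NCCC3(CCCCC3)S2)cc1`, differs from compound 1 in a single place: amino in place of isopropyl on an aromatic carbon. Among the measured compounds shown here, no pair among the measured compounds shows a change of this kind, so the expectation rests on the structural change alone. The expected step is a 2.6-fold lower number from compound 1 to compound 4 (0.42 log units; beyond the scatter), a drop in this assay that is larger than the scatter but not dramatic. Compound 4 is therefore estimated at 6 10^-6 cm/s, with a likely range from 2.5 10^-6 cm/s to 14 10^-6 cm/s.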

Compound 4, apparent permeability: 2.04 10^-6 cm/s
For compound 4 the middle estimate is 2.9-fold (0.47 log units) above the measured one; the whole stated range lies above it.
By their numbers in this assay, from the lowest: compound 4; then compounds 2, 1 and 3 (each within the scatter of the next, the first and the last beyond it).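

Among the compounds shown here, the earlier compounds offered no pair differing in one place, so this is the first clear reading of a single change on the shared core in this assay (a 7.7-fold lower number from compound 1 to compound 4 (0.89 log units; beyond the scatter)). It shows that the group on this aromatic carbon, para to a large group, can shift the number by more than repeat measurements would, which none of the earlier gaps could establish. No measurement shown here accounts for the drop.

Still open, going by these compounds, is whether the drop follows the arrival of the amino group or the departure of isopropyl, a question that a methyl, a hydroxyl or a carboxylic acid at this position could help to settle. For the compounds shown here, this change also appears in only one pair, so whether it holds elsewhere on the shared core remains unknown.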